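Chloro to fluoro on the core ring

This account rests on a few compounds, and the source may have more. Where it says the series, first, only, none or still open, it means among the compounds named here.

Measured in a functional assay on HEK293 cells for antagonist activity at prostaglandin E2 receptor EP4 subtype (Homo sapiens), read by scintillation proximity assay and cAMP accumulation; on this read-out higher numbers stand for weaker inhibition and lower numbers for stronger inhibition:
compound 1 `C[C@H](NC(=O)c1cccc2c1N(Cc1ccc(Cl)cc1Br)CC2)c1ccc(C(=O)O)cc1` gives 8.3 nM;
compound 2 `C[C@H](NC(=O)c1cc(Cl)cc2c1N(Cc1ccc(C(F)(F)F)cc1)CC2)c1ccc(C(=O)O)cc1` gives 2.2 nM.

Compound 2 stands at the lowest of the two numbers in this assay; compound 1 sits at a higher number, and that gap lies beyond the scatter. Compound 3 `C[C@H](NC(=O)c1cc(F)cc2c1N(Cc1ccc(C(F)(F)F)cc1)CC2)c1ccc(C(=O)O)cc1` differs from compound 2 by fluoro in place of chloro on an aromatic carbon. Within the data shown here, no measured pair carries this change, so its size is unknown here. In this assay the expected step is a 1.6-fold higher number from compound 2 to compound 3 (0.20 log units; within the scatter), small and most likely within the scatter, if anything toward a slightly higher number. Compound 3 is therefore estimated at 3.5 nM, with a range of 1.2 nM to 10 nM.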

Compound 3, half-maximal inhibitory concentration: 2.1 nM
Estimate against measurement, compound 3: 1.7-fold (0.22 log units) above; the range from low to high includes it.
By their numbers in this assay, from the lowest: compounds 3 and 2 (each within the scatter of the next); then compound 1.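

In this assay, among these compounds, fluoro in place of chloro on this aromatic carbon, meta to a large group, gives a 1.0-fold lower number from compound 2 to compound 3 (0.02 log units; within the scatter) as the first step that isolates one change. At this position, the read-out therefore does not separate the two halogens. Nothing on hand offers an explanation for this result. Going by these compounds, whether a nitrile, a methoxy group or a methyl group on this carbon would stay within the scatter of compound 2 remains open. Also open, on these data alone, is how hydrogen there would compare with the trifluoromethyl group retained.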